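The source may hold more compounds than are shown below. What is called first, only, known or untested is meant among the compounds shown, and "the series" means these compounds.

In an ADME assay on cells (Hepatocyte, Rattus norvegicus) for pharmacokinetics, read by LC-MS, with a stated time of 90 min, tested at 1 uM (a lower number here means slower removal, a higher number faster removal of the compound), compound 1 `CCN(C(=O)OC)c1c(N)nc(-c2nn(Cc3ccccc3F)c3ncccc23)nc1N` gives 11.7 mL/min/kg while compound 2 `COC(=O)N(CCO)c1c(N)nc(-c2nn(Cc3ccccc3F)c3ncccc23)nc1N` gives 61.7 mL/min/kg and compound 3 `COC(=O)N(Cc1ccc(F)cc1)c1c(N)nc(-c2nn(Cc3ccccc3F)c3ncccc23)nc1N` gives 40 mL/min/kg on the same shared core. Compound 2 therefore sits level with compound 3, as shown by (a 1.5-fold lower number from compound 2 to compound 3 (0.19 log units; within the scatter)), and both stand clear of compound 1. Compound 4 `CC(C)OC(=O)Nc1c(N)nc(-c2nn(Cc3ccccc3F)c3ncccc23)nc1N` carries (isopropoxycarbonyl)amino in place of (2-hydroxyethyl)(methoxycarbonyl)amino on an aromatic carbon, a swap counted here: (isopropoxycarbonyl)amino in place of (2-hydroxyethyl)(methoxycarbonyl)amino on an aromatic carbon. The hydroxyethyl chain of compound 2 is gone in compound 4, so the nearest guide is the hydroxy step (a 5.3-fold higher number from compound 1 to compound 2 (0.72 log units; beyond the scatter)), read in reverse. The step with the 4-fluorophenyl group (a 3.4-fold higher number from compound 1 to compound 3 (0.53 log units; beyond the scatter)) also points to a higher number with a larger chain on that nitrogen. Within the data shown here, no measured compound carries (isopropoxycarbonyl)amino, so this guide is only partial, and a modest drop is expected rather than the full reverse of the hydroxy step. The expected change in this assay is a 2.2-fold lower number from compound 2 to compound 4 (0.34 log units; beyond the scatter) by estimate. For compound 4 the estimated clearance is 28 mL/min/kg with an expected range from 11 mL/min/kg to 65 mL/min/kg in repeat measurements.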

Compound 4, clearance: 15 mL/min/kg
Compound 4: middle estimate off by 1.9-fold (0.27 log units), on the high side; measured number inside the range.
By their numbers in this assay, from the lowest: compounds 1 and 4 (each within the scatter of the next); then compounds 3 and 2 (each within the scatter of the next).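

In this assay, compound 4 shows that the nitrogen on this aromatic carbon needs no chain for a low number: with (isopropoxycarbonyl)amino in place of (2-hydroxyethyl)(methoxycarbonyl)amino, the result stands clear of the earlier compound (a 4.1-fold lower number from compound 2 to compound 4 (0.61 log units; beyond the scatter)). It also sits level with the ethyl-bearing compound (a 1.3-fold higher number from compound 1 to compound 4 (0.11 log units; within the scatter)), so a low number appears here both with an ethyl chain on the nitrogen and with only a hydrogen there, while the chains of compound 2 and compound 3 go with higher numbers. Nothing available explains these shifts.

The swap changes the nitrogen and the ester together, so (methoxycarbonyl)amino would be needed to tell their shares apart. Going by these compounds, how a plain amino group or a longer chain such as propyl on this nitrogen would read also remains open.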